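Methyl on the pyrazole carbon of compound 2

The compounds below may be only part of what the source reports. "The series", "measured", "known", "first", "only" and "open" are said of these compounds alone.

Compound 2 `C[C@@H]1CCCN1c1c(C#N)c2c(N)nc(Nc3cn[nH]c3)nc2n1C` stands lowest of the three measured compounds in an assay on isolated protein for binding affinity to Leucine-rich repeat serine/threonine-protein kinase 2 variant G2019S (Homo sapiens), read by TR-FRET and LanthaScreen, with a stated time of 2 h (on this read-out lower numbers stand for stronger inhibition and higher numbers for weaker inhibition), with 0.4 nM. Within the data shown here, compound 1 `Cc1nn(C)cc1Nc1nc(N)c2c(C#N)c(N3CCC[C@H]3C)n(C)c2n1` gives 2 nM in this assay, and compound 3 `Cc1cn(C)nc1Nc1cc2c(c(N)n1)c(C#N)c(N1CCC[C@H]1C)n2C` gives 75 nM, far higher than either; compound 3 differs from both in its core as well as in the pyrazole, so no single step connects it to them.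

Compound 4 `Cc1n[nH]cc1Nc1nc(N)c2c(C#N)c(N3CCC[C@H]3C)n(C)c2n1` carries methyl in place of hydrogen on an aromatic carbon, placed on an aromatic carbon of a five-membered aromatic ring with two nitrogens, two ring bonds from the ring nitrogen.

Among the measured compounds shown here, the one measured step that bears on this is a 5.0-fold lower number from compound 1 to compound 2 (0.70 log units; beyond the scatter), where both a ring-nitrogen methyl and this ring-carbon methyl were removed together. Compound 4 puts back only the carbon methyl, so it should sit between compound 2 and compound 1 in this assay. A small rise in the number is expected, a 2.3-fold higher number from compound 2 to compound 4 (0.35 log units; beyond the scatter), close to the scatter.

Compound 4 is therefore estimated at 0.9 nM in this assay, with a range from 0.35 nM to 2.5 nM.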

Compound 4, inhibition constant: 2 nM
Compound 4: middle estimate off by 2.2-fold (0.35 log units), on the low side; low and high end bracket the measured number.
By their numbers in this assay, from the lowest: compound 2; then compounds 1 and 4 (each within the scatter of the next); then compound 3.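

Methyl in place of hydrogen on the aromatic carbon is enough on its own to raise the number: in this assay the step reads a 5.0-fold higher number from compound 2 to compound 4 (0.70 log units; beyond the scatter), which matches the whole of the earlier double change, a 5.0-fold lower number from compound 1 to compound 2 (0.70 log units; beyond the scatter). With that carbon methyl in place, hydrogen in place of methyl on the aromatic nitrogen gives no change at the digits printed from compound 1 to compound 4 (within the scatter), so in this pair the rise follows the carbon methyl and the nitrogen methyl leaves no readable mark. No measurement at hand speaks to why this carbon methyl raises the number.

Open, from the compounds shown here alone, is whether ethyl, methoxy or fluoro on this aromatic carbon would change the number as methyl does. Also open, going by these compounds, is whether methyl on the ring nitrogen stays without readable effect when hydrogen stands on the carbon, as in 1-methyl-1H-pyrazol-4-yl.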